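The source may report more compounds than this note shows. Statements on the series, on what has been measured and on what is new or still open speak of the compounds shown alone.

Measured compounds:
- compound 1 `COc1cc(-c2cc(/C=C/C(=O)c3ccc(C)cc3)nc3cc(-c4ccccc4)nn23)cc(OC)c1OC` — 23900 nM
- compound 2 `COc1ccc(C(=O)/C=C/c2cc(-c3ccc(OC)c(OC)c3)n3nc(-c4ccccc4)cc3n2)cc1OC` — 2600 nM

In a functional assay on MDA-MB-231 cells (Homo sapiens) for antiproliferative activity, read by MTT assay, with a stated time of 24 h (on this read-out higher numbers stand for weaker inhibition and lower numbers for stronger inhibition), compound 2 gives 2600 nM, the lower of the two numbers obtained; compound 1 gives 23900 nM, a higher number that lies beyond the scatter of the read-out. The two share the core but differ in more than one place, so nothing is computed between them.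

Compound 3 `COc1ccc(C(=O)/C=C/c2cc(-c3cc(OC)c(OC)c(OC)c3)n3nc(-c4ccccc4)cc3n2)cc1OC` follows from compound 2 by one change: methoxy in place of hydrogen on an aromatic carbon. For the measured compounds named here, no measured pair in this set isolates that change, so its size is unknown here. The expectation for the step is a small one, within the scatter or at most a modest move toward a lower number, as indicated by the estimated step of a 1.3-fold lower number from compound 2 to compound 3 (0.11 log units; within the scatter). On that basis compound 3 is expected to give about 2000 nM in this assay, with a range from 600 nM to 7000 nM.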

Compound 3, half-maximal inhibitory concentration: 18300 nM
For compound 3 the middle estimate is 9.2-fold (0.96 log units) below the measured one, outside the stated range (above it).
By their numbers in this assay, from the lowest: compound 2; then compounds 3 and 1 (each within the scatter of the next).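

In this assay, methoxy in place of hydrogen on this aromatic carbon, ortho to a methoxy group, turns 3,4-dimethoxyphenyl into 3,4,5-trimethoxyphenyl and gives a 7.0-fold higher number from compound 2 to compound 3 (0.85 log units; beyond the scatter), so this position responds to the added group, which the two earlier compounds, differing in more than one place, could not show. On the carbonyl carbon, 3,4-dimethoxyphenyl in place of 4-methylphenyl gives a 1.3-fold lower number from compound 1 to compound 3 (0.12 log units; within the scatter), so with the trimethoxyphenyl present this exchange does not separate the two compounds. Nothing at hand explains the rise at this position.

Whether the response follows from methoxy alone stays open, since a smaller group such as fluorine, a hydroxy group or an amine on this carbon is not among the compounds shown. From the compounds shown here alone, whether the carbonyl-side exchange would also stay within the scatter with 3,4-dimethoxyphenyl in place of the trimethoxyphenyl also remains open.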